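Swapping an amide substituent in a methoxyquinoline series

The source may report more compounds than this note shows. Statements on the series, on what has been measured and on what is new or still open speak of the compounds shown alone.

Measured so far:
Compound 1 `COc1ccc2nc(C)cc(OCc3ccc4ccccc4n3)c2c1`: 5.48
Compound 2 `COc1ccc2nc(C)cc(OCC(=O)NCc3cc(C)cc(C)c3)c2c1`: 5.25

In a physicochemical assay for lipophilicity, read by HPLC, in phosphate buffer, measured as chromatographic lipophilicity, at pH 7.4 (on this read-out higher numbers stand for higher lipophilicity and lower numbers for lower lipophilicity), compound 2 gives 5.25, the lower of the two numbers, yet it sits within the scatter of compound 1, so the two cannot be ordered. Compound 3 `COc1ccc2nc(C)cc(OCC(=O)Nc3noc(C)c3C)c2c1` is not yet measured. It differs from compound 2 in one place (4,5-dimethyl-1,2-oxazol-3-yl in place of 3,5-dimethylbenzyl on an amide-type nitrogen). Among the measured compounds shown here, no step between measured compounds is known here, so any expectation rests on the change alone. A downward step in this assay beyond the scatter is expected, estimated as a number 1.35 log units lower from compound 2 to compound 3 (beyond the scatter). For compound 3 the expected value is 3.9, with a range from 3.3 to 4.5.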

Compound 3, distribution coefficient: 3.3
The estimate for compound 3 lay 0.60 log units above the measured number; measured number inside the range.
By their numbers in this assay, from the lowest: compound 3; then compounds 2 and 1 (each within the scatter of the next).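

In this assay, placing 4,5-dimethyl-1,2-oxazol-3-yl instead of 3,5-dimethylbenzyl on the amide-type nitrogen gives a number 1.95 log units lower from compound 2 to compound 3 (beyond the scatter), a large step. Among the compounds shown here, this shows that the read-out responds strongly to the group at this place, which compound 1 and compound 2 alone could not show, as no single-place step linked them. Nothing measured here explains the size of this step.

The compounds shown leave open how an unsubstituted phenyl or a plain benzyl on this nitrogen would read. They also leave open where a carboxylic acid or an amine on a longer chain would fall.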